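A few compounds are considered here, and "the series" means these few. Any claim that something is new, unique, unknown or untested is made for them only; others in the source may bear on it.

Measured compounds in a functional assay on HeLa cells (Homo sapiens) for cytotoxicity, read by MTT assay, with a stated time of 48 h; on this read-out higher numbers stand for weaker inhibition and lower numbers for stronger inhibition:
- compound 1 `Cc1ccc(Cn2cc(COc3ccc4c(=O)ccoc4c3)nn2)cc1`: > 100000 nM
- compound 2 `O=c1ccoc2cc(OCc3cn(Cc4ccc(F)cc4)nn3)ccc12`: 12000 nM
- compound 3 `O=c1ccoc2cc(OCc3cn(Cc4cccc([N+](=O)[O-])c4)nn3)ccc12`: 17300 nM

The value of compound 1 is a limit of the assay, not a number (the limit of > 100000 nM in this assay, at which 1 of the 3 values shown sits). Compound 4 `O=c1ccoc2cc(OCc3cn(Cc4ccccc4Cl)nn3)ccc12` differs from compound 1 in one place: 2-chlorophenyl in place of 4-methylphenyl on a saturated chain carbon bound to an aromatic nitrogen. Two measured steps start from compound 1 and exchange the same group: an at least 8.3-fold lower number from compound 1 to compound 2 (0.92 log units; beyond the scatter) and an at least 5.7-fold lower number from compound 1 to compound 3 (0.76 log units; beyond the scatter). Both exchanges moved the number well below the limit, and the two products sit close together (a 1.4-fold higher number from compound 2 to compound 3 (0.16 log units; within the scatter)). The change to 2-chlorophenyl is therefore expected to give a lower number of a similar size, an at least 6.6-fold lower number from compound 1 to compound 4 (0.82 log units; beyond the scatter). Compound 4 is estimated at 15000 nM, within a range from 5000 nM to 60000 nM.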

Compound 4, half-maximal inhibitory concentration: > 100000 nM
Compound 4 was reported as a limit; the forecaster's own chance of this, stated with the estimate: 20%; at least 6.6-fold (0.82 log units) between middle value and limit.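

The value of compound 4 in this assay is a limit, not a number: the limit of > 100000 nM in this assay, at which 2 of the 4 values shown sit. Swapping out 4-methylbenzyl therefore does not by itself give a readable number, and the new group matters: 2-chlorobenzyl gives an at least 8.3-fold higher number from compound 2 to compound 4 (0.92 log units; beyond the scatter) and an at least 5.7-fold higher number from compound 3 to compound 4 (0.76 log units; beyond the scatter). The step from compound 1 to compound 4 cannot be read, as both values are limits.

Still open, from the compounds shown here alone, is whether an amine or a carboxylic acid on the phenyl ring would give a readable number. Going by these compounds, the effect of a longer chain between the phenyl ring and the aromatic nitrogen is also open.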